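A few compounds are considered here, and "the series" means these few. Any claim that something is new, unique, unknown or untested is made for them only; others in the source may bear on it.

Measured in a functional assay on MOLT-4 cells (Homo sapiens) for inhibition; on this read-out higher numbers stand for weaker inhibition and lower numbers for stronger inhibition:

compound 1 `CC(=O)OCCOn1cnc2c(Cl)nc(N)nc21` gives > 500000 nM, which is a limit of the assay and not a number.
compound 2 `CC(=O)OC(C)n1cnc2c(Cl)nc(I)nc21` gives 12300 nM.
compound 3 `CC(=O)OCCOn1cnc2c(S)nc(N)nc21` gives 8900 nM.

Among these, compound 3 and compound 2 give numbers that lie within the usual scatter of each other, so neither can be set ahead of the other. Compound 1 stands apart at the limit of > 500000 nM in this assay, at which 1 of the 3 values shown sits. Within the data shown here, the one measured step between two compounds that differ in a single place is the one in this assay from compound 1 to compound 3, an at least 56-fold lower number from compound 1 to compound 3 (1.74 log units; beyond the scatter), where sulfanyl replaces chloro on an aromatic carbon.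

Compound 4 `CC(=O)OCCOn1cnc2c(S)nc(F)nc21` differs from compound 3 in another place: fluoro in place of amino on an aromatic carbon. Among the measured compounds shown here, no measured pair in this set changes the amino group, so the step from compound 1 to compound 3 gives no direct guide to how this exchange will act. With nothing to anchor a direction, the estimate for compound 4 stays close to compound 3 and carries a wide range on either side, and the step it implies, a 1.1-fold higher number from compound 3 to compound 4 (0.05 log units; within the scatter), is expected to be small relative to that range. The expected value for compound 4 in this assay is 10000 nM, between 2000 nM and 60000 nM.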

Compound 4, half-maximal inhibitory concentration: 35000 nM
Compound 4: the middle estimate sits 3.5-fold (0.54 log units) below what was measured; low and high end bracket the measured number.
By their numbers in this assay, from the lowest: compounds 3 and 2 (each within the scatter of the next); then compound 4. At a limit, above all of these: compound 1.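

In this assay, among these compounds, the exchange of amino for fluoro on the aromatic carbon between two ring nitrogen atoms gives a 3.9-fold higher number from compound 3 to compound 4 (0.59 log units; beyond the scatter) and so shows that this position affects the read-out, which the earlier steps could not show because none of them changed this group. The step is only modest, and the amino group is not required for a measurable result when the sulfanyl group is present: compound 4 still gives 35000 nM. The data show the size of this step but offer no measurement that explains it.

On these data alone, it remains open whether a hydroxyl or a methylamino group on this carbon would give a number closer to that of compound 3 or to that of compound 4, which would help separate what the amino group itself contributes from the simple loss of it. As far as these compounds go, it also remains open whether the same exchange would have a similar effect with a methylsulfanyl group in place of the sulfanyl group.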